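This account rests on a few compounds, and the source may have more. Where it says the series, first, only, none or still open, it means among the compounds named here.

Measured compounds:
Compound 1 `Cc1ccnc(/C(N)=N/NC(=S)N2CCSCC2)c1`: 91.6%
Compound 2 `N/C(=N\NC(=S)N1CCSCC1)c1ccccn1`: 88.7%
Compound 3 `Cc1cccc(/C(N)=N/NC(=S)N2CCCCCC2)n1`: 82.7%

All three were tested in a functional assay on HeLa cells (Homo sapiens) for cytotoxicity, read by MTT assay, with a stated time of 72 h, tested at 100 uM; on this read-out higher numbers stand for more inhibition of growth at the one concentration tested and lower numbers for less inhibition of growth. Compound 1 has the largest of the three numbers, but neither of the other two differs from it by more than the usual scatter. Among the compounds with values here, the only single-point step among them is a number 2.9 percentage points lower from compound 1 to compound 2 (within the scatter), a change that leaves the read-out essentially unchanged. Compound 3 differs from compound 1 in two places, including the ring on the thiocarbonyl carbon, and its number, too, is close to that of compound 1.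

Compound 4 `Cc1ccnc(/C(N)=N/NC(=S)N2CCCC2)c1` has not been measured. It differs from compound 1 by pyrrolidin-1-yl in place of thiomorpholin-4-yl on a thiocarbonyl carbon. Within the data shown here, no measured step covers this exact change; the nearest hint is that compound 3, with a different ring at the same place, gives a number near that of compound 1. A step of no more than the scatter is therefore expected in this assay, as a number 6.6 percentage points lower from compound 1 to compound 4 (within the scatter). Compound 4 is estimated at 85%, with a range from 68% to 96%.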

Compound 4, percent growth inhibition at one concentration: 88.1%
For compound 4 the middle estimate is 3.1 percentage points below the measured one, and the stated range covers the measured number.
By their numbers in this assay, from the lowest: compounds 3, 4, 2 and 1 (each within the scatter of the next).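

Within the data shown here, compound 4 shows the group on the thiocarbonyl carbon changed with the rest of compound 1 kept the same, which the earlier compounds did not offer. In this assay pyrrolidin-1-yl in place of thiomorpholin-4-yl gives a number 3.5 percentage points lower from compound 1 to compound 4 (within the scatter) and so leaves the read-out essentially unchanged, even though the ring loses its sulfur and goes from six-membered to five-membered. No measurement shown here accounts for this result.

As far as these compounds go, all these numbers come from the one concentration tested, so whether the compounds would still match at lower concentrations stays open. Also open, from the compounds shown here alone, is how morpholin-4-yl, with oxygen in place of the ring sulfur, or an open-chain dimethylamino group would behave on the same thiocarbonyl carbon.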